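A few compounds are considered here, and "the series" means these few. Any claim that something is new, unique, unknown or untested is made for them only; others in the source may bear on it.

Measured so far:
compound 1 `COc1ccc([C@@H]2C/C(=N/OCc3cn(-c4ccc(Cl)cc4C)nn3)c3cc(CC=C(C)C)c(OC)cc3O2)cc1`: 49%
compound 2 `COc1ccc([C@@H]2C/C(=N/OCc3cn(-c4ccc(NC(=O)c5ccccc5)cc4)nn3)c3cc(CC=C(C)C)c(OC)cc3O2)cc1`: 22%

In a functional assay on PC-3 cells (Homo sapiens) for inhibition, read by sulforhodamine B assay, with a stated time of 48 h, tested at 50 uM (a lower number here means less inhibition of growth, a higher number more inhibition of growth at the concentration tested), compound 1 gives 49%. In this assay compound 2 gives 22%, the lowest of the two numbers; its nearest neighbour, compound 1, stands higher by a margin beyond the scatter. For the measured compounds named here, the two compounds differ in more than one place, so no single-change step between measured compounds is available, and the measured pair says nothing direct about the change now at hand.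

Compound 3 `COc1ccc([C@@H]2C/C(=N/OCc3cn(-c4ccc(NC(C)=O)cc4)nn3)c3cc(CC=C(C)C)c(OC)cc3O2)cc1` differs from compound 2 in one place: methyl in place of phenyl on a carbonyl carbon. The benzamido of compound 2 becomes acetamido in compound 3. Going by the values given here, no measured pair shows the effect of such a change in this assay. The step in this assay is therefore expected to be small, a number 3 percentage points higher from compound 2 to compound 3 (within the scatter), with no direction beyond the scatter. Compound 3 is expected to give 25% in this assay, within 5% to 45%.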

Compound 3, percent growth inhibition at one concentration: 2%
For compound 3 the middle estimate is 23 percentage points above the measured one, outside the stated range (below it).
By their numbers in this assay, from the lowest: compound 3; then compound 2; then compound 1.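

In this assay, methyl in place of phenyl on a carbonyl carbon is not a neutral change: the step reads a number 20 percentage points lower from compound 2 to compound 3 (beyond the scatter) and leaves compound 3 at 2%, the lowest number of the three. With 4-acetamidophenyl in place of 4-chloro-2-methylphenyl on an aromatic nitrogen, the step is larger, a number 47 percentage points lower from compound 1 to compound 3 (beyond the scatter), so growth inhibition in this small set depends on both the aryl group on that nitrogen and the group on the carbonyl carbon. Nothing at hand explains either step.

Open, going by these compounds, is whether the aromatic ring of the benzoyl group is itself required, or whether a longer chain or a cyclohexyl group on the carbonyl carbon would serve as well. Also open, on these data alone, is how a free amine or a carboxylic acid in place of the amide would read.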